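The source may hold more compounds than are shown below. What is called first, only, known or untested is meant among the compounds shown, and "the series" means these compounds.

Measured in an assay on cells for inhibition of Ectonucleotide pyrophosphatase/phosphodiesterase family member 1 (Homo sapiens), with a stated time of 60 min, tested at 1 uM; on this read-out higher numbers stand for more inhibition at the one concentration tested (going by the name of the read-out) and lower numbers for less inhibition:
compound 1, `COc1cc2nc(/C=C/c3ccccc3)nc(N3CCC(CCNS(N)(=O)=O)CC3)c2cc1OC`: 33%
compound 2, `COc1cc2nc(/C=C/c3cccnc3)nc(N3CCC(CCNS(N)(=O)=O)CC3)c2cc1OC`: 86%
compound 3, `COc1cc2nc(/C=C/c3ccccc3F)nc(N3CCC(CCNS(N)(=O)=O)CC3)c2cc1OC`: 78%

Compound 2 gives the highest number of the three, but its step to compound 3, a number 8 percentage points lower from compound 2 to compound 3 (within the scatter), lies within the scatter, so the two cannot be ordered. Only compound 1 is set clearly apart, by a number 53 percentage points higher from compound 1 to compound 2 (beyond the scatter) and a number 45 percentage points higher from compound 1 to compound 3 (beyond the scatter).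

Compound 4, `COc1ccccc1/C=C/c1nc(N2CCC(CCNS(N)(=O)=O)CC2)c2cc(OC)c(OC)cc2n1`, differs from compound 2 as 2-methoxyphenyl in place of pyridin-3-yl on a double-bonded chain carbon bound to a double-bonded chain carbon. Going by the values given here, the steps that bear on it are a number 53 percentage points higher from compound 1 to compound 2 (beyond the scatter), large, and a number 8 percentage points lower from compound 2 to compound 3 (within the scatter), within the scatter: 2-fluorophenyl on this chain carbon has matched pyridin-3-yl, while phenyl fell well short. Among the compounds with values here, no measured compound carries 2-methoxyphenyl there. The expected step of a number 11 percentage points lower from compound 2 to compound 4 (beyond the scatter) in this assay is therefore small, within or near the scatter, leaning slightly downward. Compound 4 is estimated at 75%, range 50% to 92%.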

Compound 4, a percentage reported as inhibition, at one concentration (the size of the read-out at that concentration, not a potency): 74%
Beside the measured number, compound 4's estimate is 1 percentage points above it; the measured number falls inside the stated range.
By their numbers in this assay, from the lowest: compound 1; then compounds 4, 3 and 2 (each within the scatter of the next, the first and the last beyond it).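

In this assay, 2-methoxyphenyl on this chain carbon also stands well clear of phenyl, a number 41 percentage points higher from compound 1 to compound 4 (beyond the scatter), so the gain over phenyl now holds for all three replacements shown. Methoxy and fluoro cannot be told apart on this aromatic carbon, a number 4 percentage points lower from compound 3 to compound 4 (within the scatter), whereas the change from pyridin-3-yl is a modest loss, a number 12 percentage points lower from compound 2 to compound 4 (beyond the scatter). No evidence at hand accounts for these differences. Still open, going by these compounds, is whether an amine or a carboxylic acid in place of methoxy would hold this level of inhibition.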